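Compound 2 and a pyridin-2-yl exchange

This account rests on a few compounds, and the source may have more. Where it says the series, first, only, none or still open, it means among the compounds named here.

In a functional assay on K562 cells (Homo sapiens) for cytotoxicity, read by ELISA, with a stated time of 4 days (a lower number here means a stronger inhibitor, a higher number a weaker inhibitor), compound 1 (`Cc1ccsc1-c1cc(-c2ccco2)cc(-c2ccc(Cl)cc2)n1`) gives 20700 nM and compound 2 (`Cc1ccc(-c2cc(-c3ccoc3)cc(-c3ccc(Cl)s3)n2)o1`) gives 12700 nM as its reading, which places the two within the scatter of each other. Compound 3 (`Clc1ccc(-c2cc(-c3ccoc3)cc(-c3ccccn3)n2)s1`) carries pyridin-2-yl in place of 5-methylfuran-2-yl on an aromatic carbon. Among the compounds with values here, no measured pair shows this exchange, so no step beyond the scatter is expected in this assay in either direction. The estimated change is small, with a 1.3-fold lower number from compound 2 to compound 3 (0.10 log units; within the scatter) as the expected step. For compound 3 the expected value is 10000 nM (estimated range 3000 nM to 30000 nM).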

Compound 3, half-maximal inhibitory concentration: 20000 nM
The estimate for compound 3 lay 2.0-fold (0.30 log units) below the measured number; measured number inside the range.
By their numbers in this assay, from the lowest: compounds 2, 3 and 1 (each within the scatter of the next).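

At the carbon next to the ring nitrogen, a six-membered pyridin-2-yl ring stands in place of the five-membered 5-methylfuran-2-yl ring with no step beyond the scatter in this assay (a 1.6-fold higher number from compound 2 to compound 3 (0.20 log units; within the scatter)). This pair therefore shows that, in this one setting, the reading does not separate these two aromatic rings. Nothing measured on these compounds offers an explanation for this result. Still open, on these data alone, is whether an amine, a carboxylic acid or a longer alkyl chain at this carbon would give a step beyond the scatter. Also open, as far as these compounds go, is whether this exchange behaves alike when the 5-chlorothiophen-2-yl and furan-3-yl groups are replaced.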